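Amide chain length and antiproliferative potency in breast cancer cells

A few compounds are considered here, and "the series" means these few. Any claim that something is new, unique, unknown or untested is made for them only; others in the source may bear on it.

compound 1, `CCCCC(=O)Nc1cc2ccc(O[C@@H]3OC(C)(C)[C@H](OC)[C@@H](O)[C@H]3O)c(C)c2oc1=O`: 118000 nM
compound 2, `CO[C@@H]1[C@@H](O)[C@@H](O)[C@H](Oc2ccc3cc(NC(C)=O)c(=O)oc3c2C)OC1(C)C`: > 900000 nM

In a functional assay on SK-BR-3 cells (Homo sapiens) for antiproliferative activity (a higher number here means a weaker inhibitor, a lower number a stronger inhibitor), compound 1 gives 118000 nM. For compound 2 only a limit is known, > 900000 nM. Compound 2 thus stands at the limit of > 900000 nM in this assay, at which 1 of the 2 values shown sits, with no number below it. Compound 3, `CCCCCC(=O)Nc1cc2ccc(O[C@@H]3OC(C)(C)[C@H](OC)[C@@H](O)[C@H]3O)c(C)c2oc1=O`, differs from compound 2 by butyl in place of hydrogen on a saturated chain carbon bound to a carbonyl carbon. Among the measured compounds shown here, the single measured step that bears on this, an at least 7.6-fold higher number from compound 1 to compound 2 (0.88 log units; beyond the scatter), runs the opposite way, from propyl to hydrogen. Reversing it and lengthening the chain from propyl to butyl, compound 3 is expected to give a lower number, a step of about an at least 11-fold lower number from compound 2 to compound 3 (1.05 log units; beyond the scatter). The estimate for compound 3 is 80000 nM, from 25000 nM to 300000 nM.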

Compound 3, half-maximal inhibitory concentration: 84000 nM
The estimate for compound 3 lay 1.1-fold (0.02 log units) below the measured number, within the range that was stated.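

In this assay, butyl in place of hydrogen at this saturated chain carbon gives an at least 10-fold lower number from compound 2 to compound 3 (1.02 log units; beyond the scatter). That step rests on a limit rather than a number for compound 2: the limit of > 900000 nM in this assay, at which 1 of the 3 values shown sits. Adding methyl to the chain gives a 1.4-fold lower number from compound 1 to compound 3 (0.15 log units; within the scatter), so the two longer chains cannot be told apart, and the step from acetamido to a longer amide shows no further measurable gain at this length. As far as these compounds go, what stays open is how a chain longer than butyl would read, and whether an amine or a carboxylic acid at the chain end would change the number.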